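This account rests on a few compounds, and the source may have more. Where it says the series, first, only, none or still open, it means among the compounds named here.

Compound 3 `Cc1c(OCCCCOc2ccccc2C(=O)O)ccc(C(=O)CC(C)C)c1O` stands second highest of the three compounds measured in an assay on HEK293 cells for positive allosteric modulation of metabotropic glutamate receptor 2 (Rattus norvegicus), read by thallium flux, with a stated time of 2.5 min (on this read-out lower numbers stand for smaller maximal responses and higher numbers for larger maximal responses), where compound 3 gives 92.4%. Its nearest neighbour is compound 1 `Cc1c(OCCCCOc2ccc(F)c(C(=O)O)c2)ccc(C(=O)CC(C)(C)C)c1O`, which in this assay gives 94.6%, within the scatter of compound 3. Furthest lies compound 2 `Cc1c(OCCCCOc2ccc(C(=O)O)c(Cl)c2)ccc(C(=O)CC(C)C)c1O`, which in this assay gives 80.5%; the only step shown, a number 11.9 percentage points higher from compound 2 to compound 3 (beyond the scatter), lies beyond the scatter and is modest in size. Compound 4 `Cc1c(OCCCCOc2ccc(F)c(C(=O)O)c2)ccc(C(=O)CC(C)C)c1O` differs from compound 3 in one place: 3-carboxy-4-fluorophenyl in place of 2-carboxyphenyl on an oxygen on a saturated carbon. No measured step exchanges these two groups directly, so the move is judged from compound 1, which carries the same 3-carboxy-4-fluorophenyl group but differs elsewhere, and from the modest size of the one step shown. In this assay compound 1 gives 94.6%. Little change beyond the scatter is therefore expected, and compound 4 is estimated at 93% with a range from 82% to 100%. The step this estimate implies, a number 0.6 percentage points higher from compound 3 to compound 4 (within the scatter), is expected to stay within the scatter.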

Compound 4, largest response reached (reported as percent of maximum), in percent of the reference or control that the assay uses: 84.5%
For compound 4 the middle estimate is 8.5 percentage points above the measured one; the measured number falls inside the stated range.
By their numbers in this assay, from the lowest: compounds 2, 4, 3 and 1 (each within the scatter of the next, the first and the last beyond it).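

In this assay, 3-carboxy-4-fluorophenyl on the oxygen gives a number 7.9 percentage points lower from compound 3 to compound 4 (within the scatter) when it replaces 2-carboxyphenyl and a number 4 percentage points higher from compound 2 to compound 4 (within the scatter) when it replaces 4-carboxy-3-chlorophenyl, so compound 4 cannot be separated from either of these two compounds. The clearer change lies at the other end of the molecule: hydrogen in place of methyl on the saturated chain carbon bound to three saturated chain carbons gives a number 10.1 percentage points lower from compound 1 to compound 4 (beyond the scatter) in a modest step. The high number of compound 1 therefore does not come with the 3-carboxy-4-fluorophenyl group alone.

On these data alone, this methyl step is seen with that one group only, so it remains open whether it holds with 2-carboxyphenyl or 4-carboxy-3-chlorophenyl. As far as these compounds go, it is also open how a tetrazole in place of the carboxylic acid would read. Nothing given here explains any of these differences.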